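A few compounds are considered here, and "the series" means these few. Any claim that something is new, unique, unknown or untested is made for them only; others in the source may bear on it.

Compound 1 `O=C(Nc1cccc(-c2oc3cc(-c4ccc(F)cc4)ccc3c(=O)c2O)c1)c1ccc(Br)cc1F`: > 100000 nM in a functional assay on HepG2 cells (Homo sapiens) for antiproliferative activity, read by CCK-8 assay, with a stated time of 72 h (on this read-out lower numbers stand for stronger inhibition and higher numbers for weaker inhibition), which is a limit of the assay rather than a number.
Compound 2 `Cc1cc(C(=O)Nc2cccc(-c3oc4cc(-c5ccc(F)cc5)ccc4c(=O)c3O)c2)ccc1F`: 9540 nM in this assay.

Compound 2 therefore holds the only number shown in this assay; the other value is a limit. For the measured compounds named here, the one measured step that bears on the changed place is an at least 10-fold lower number from compound 1 to compound 2 (1.02 log units; beyond the scatter), and it starts from the limit of > 100000 nM in this assay, at which 1 of the 2 values shown sits, so its true size is not fully known. Compound 3 `N#Cc1ccc(C(=O)Nc2cccc(-c3oc4cc(-c5ccc(F)cc5)ccc4c(=O)c3O)c2)cc1` differs from compound 2 by 4-cyanophenyl in place of 4-fluoro-3-methylphenyl on a carbonyl carbon. Going by the values given here, the single measured step shows that the group on the carbonyl carbon can shift the read-out strongly, but no measured compound carries a 4-cyanophenyl there, so the direction of the change cannot be read from the data. The expected step is a 1.3-fold higher number from compound 2 to compound 3 (0.10 log units; within the scatter), none beyond the scatter, with a wide range. For compound 3 the estimated value in this assay is 12000 nM, between 2500 nM and 60000 nM.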

Compound 3, half-maximal inhibitory concentration: 7110 nM
Compound 3: the middle estimate sits 1.7-fold (0.23 log units) above what was measured, within the range that was stated.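

Replacing 4-fluoro-3-methylphenyl with 4-cyanophenyl on the carbonyl carbon makes no clear difference in this assay: the result is a 1.3-fold lower number from compound 2 to compound 3 (0.13 log units; within the scatter), so these two different groups cannot be told apart here. The second comparison gives an at least 14-fold lower number from compound 1 to compound 3 (1.14 log units; beyond the scatter), so 4-bromo-2-fluorophenyl now stands apart from two other groups rather than one. Compound 1 has a limit and not a number, so the true size of that step is not fully known: the limit of > 100000 nM in this assay, at which 1 of the 3 values shown sits.

Going by these compounds, whether the bromine, the fluorine or the two together set 4-bromo-2-fluorophenyl apart remains open. On these data alone, it is also open how this assay would respond to a phenyl ring carrying an amine or a carboxylic acid, or to a longer chain in place of the ring.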